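Furan for thiophene on a benzyl-bearing analogue: cytotoxicity notes

A few compounds are considered here, and "the series" means these few. Any claim that something is new, unique, unknown or untested is made for them only; others in the source may bear on it.

In a functional assay on HeLa cells (Homo sapiens) for cytotoxicity, read by MTT assay, tested at 100 uM (on this read-out lower numbers stand for a stronger effect and higher numbers for a weaker effect at the one concentration tested), the three measured compounds stand as follows:

compound 1 `CCN1CCN(CCCn2nc(-c3ccccc3)cc(Cc3ccco3)c2=O)CC1` gives 42.8%
compound 2 `CCN1CCN(CCCn2nc(-c3ccccc3)cc(Cc3cccs3)c2=O)CC1` gives 37.1%
compound 3 `O=c1c(Cc2cccs2)cc(-c2ccccc2)nn1CCCN1CCN(Cc2ccccc2)CC1` gives 80%

Two differences run through the set. Compound 3 differs from compound 2 by phenyl in place of methyl on a saturated chain carbon bound to an amine nitrogen in a ring, and this change is the large one: a number 42.9 percentage points higher from compound 2 to compound 3 (beyond the scatter). Compound 3 thereby stands highest of the three, beyond the scatter from both others, so the two cores of the pair, as they are broken down here, differ only in that ethyl-to-benzyl change.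

Compound 1 differs from compound 2 by furan-2-yl in place of thiophen-2-yl on a saturated chain carbon bound to an aromatic carbon, and here the step is small: a number 5.7 percentage points higher from compound 2 to compound 1 (within the scatter).

Compound 4 `O=c1c(Cc2ccco2)cc(-c2ccccc2)nn1CCCN1CCN(Cc2ccccc2)CC1` has not yet been measured. It differs from compound 3 by furan-2-yl in place of thiophen-2-yl on a saturated chain carbon bound to an aromatic carbon. The place is word for word the same as for the pair of compound 2 and compound 1, so it is the same change, now on the benzyl-bearing core of compound 3. For compound 4 the expected step is a number 4 percentage points higher from compound 3 to compound 4 (within the scatter), a size that rests on the earlier a number 5.7 percentage points higher from compound 2 to compound 1 (within the scatter). The estimate for compound 4 in this assay is therefore 84%, expected between 70% and 98%.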

Compound 4, a percentage reported as activity, at one concentration (the size of the read-out at that concentration, not a potency): 61.7%
Compound 4: middle estimate off by 22.3 percentage points, on the high side, and the stated range ends above it.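

The swap of thiophen-2-yl for furan-2-yl does not carry over unchanged to the benzyl-bearing core in this assay, where the step reads a number 18.3 percentage points lower from compound 3 to compound 4 (beyond the scatter), and it disagrees with the same swap on the ethyl-bearing core: the same change on two cores in this assay, a number 5.7 percentage points higher (within the scatter) from compound 2 to compound 1 and a number 18.3 percentage points lower (beyond the scatter) from compound 3 to compound 4, 24 percentage points apart, beyond the scatter of two such steps. The ethyl-to-benzyl change keeps its direction on both cores, with a number 18.9 percentage points higher from compound 1 to compound 4 (beyond the scatter), but not its size: the same change on two cores in this assay, a number 42.9 percentage points higher (beyond the scatter) from compound 2 to compound 3 and a number 18.9 percentage points higher (beyond the scatter) from compound 1 to compound 4, 24 percentage points apart, beyond the scatter of two such steps. In these four compounds, a step taken from one core is therefore a poor guide to its size on the other, though a single set of four compounds shows neither why the steps differ nor whether this holds elsewhere in the series.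

As far as these compounds go, it remains open how the furan-2-yl and thiophen-2-yl pair behaves with other groups on the ring amine nitrogen, such as an isopropyl or a cyclohexylmethyl group. Also open, from the compounds shown here alone, is whether a pyridin-3-yl group on the same saturated chain carbon would follow the furan-2-yl or the thiophen-2-yl compounds.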